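A few compounds are considered here, and "the series" means these few. Any claim that something is new, unique, unknown or untested is made for them only; others in the source may bear on it.

Measured in a functional assay on HT-29 cells (Homo sapiens) for cytotoxicity, read by MTT assay, with a stated time of 72 h; on this read-out lower numbers stand for stronger inhibition and higher numbers for weaker inhibition:
Compound 1 `CN(C)CCCNc1nc(-c2ccc(NC(=O)Nc3ccc(Cl)cc3)cc2)nc2c(Cl)c(Cl)sc12`: 330 nM
Compound 2 `CN(C)CCNc1nc(-c2ccc(NC(=O)Nc3ccc(F)cc3)cc2)nc2ccsc12`: 350 nM
Compound 3 `CN(C)CCNc1nc(-c2ccc(NC(=O)Nc3ccc(Cl)cc3Cl)cc2)nc2c(Cl)c(Cl)sc12`: 1280 nM

Compound 2 holds the second highest of the three numbers. Its nearest neighbour is compound 1, whose number is within the scatter of it; its furthest is compound 3, whose higher number lies beyond the scatter. For the measured compounds named here, no two measured compounds differ in one place only, so no single-point step is available for calibration.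

Going by the values given here, compound 4 `Cc1ccc(NC(=O)Nc2ccc(-c3nc(NCCN(C)C)c4sccc4n3)cc2)cc1` is the one open compound. Against compound 2 the difference reads (methyl in place of fluoro on an aromatic carbon), methyl in place of fluoro on an aromatic carbon. Among the compounds with values here, nothing among the measured compounds isolates this exchange. In this assay a step no larger than the scatter is expected, in either direction. Compound 4 is estimated at 400 nM, range 150 nM to 1100 nM, which means an expected step of a 1.1-fold higher number from compound 2 to compound 4 (0.06 log units; within the scatter).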

Compound 4, half-maximal inhibitory concentration: 2150 nM
The estimate for compound 4 lay 5.4-fold (0.73 log units) below the measured number, outside the stated range (above it).
By their numbers in this assay, from the lowest: compounds 1 and 2 (each within the scatter of the next); then compounds 3 and 4 (each within the scatter of the next).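

In this assay, methyl in place of fluoro on this aromatic carbon, para to a large group, gives a 6.1-fold higher number from compound 2 to compound 4 (0.79 log units; beyond the scatter). For the compounds shown here, this is the first single-place step, and it shows that exchanging one heavy atom here, with no change in hydrogen-bond donors, acceptors or net charge, can move the number beyond the scatter. No measurement available bears on what lies behind this step. Still open, on these data alone, is where methoxy, nitrile or trifluoromethyl at this place would stand relative to fluoro and methyl. As far as these compounds go, whether the exchange gives a similar step on the core of compound 1 is also open.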